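The source may report more compounds than this note shows. Statements on the series, on what has been measured and on what is new or still open speak of the compounds shown alone.

Compound 1 `O=C(Nc1nn[nH]n1)c1cccc(-c2ccccc2)n1` is the simplest of three measured compounds built on a shared core. In a functional assay on the whole organism for inhibition, with Rattus norvegicus as the target, at a dose of 10 mg/kg by the oral route (a lower number here means a weaker effect, a higher number a stronger effect of the compound at the dose given), compound 1 gives 81%. Compound 2 `Cc1cc(C(=O)Nc2nn[nH]n2)nc(-c2ccccc2)c1` differs from it by methyl in place of hydrogen on an aromatic carbon, and in this assay compound 2 gives 88%; that change made a number 7 percentage points higher from compound 1 to compound 2 (within the scatter). Compound 3 `CCCCc1cc(C(=O)Nc2nn[nH]n2)nc(-c2ccccc2)c1` differs from compound 1 by butyl in place of hydrogen on an aromatic carbon. In this assay compound 3 gives 100%, the top of the scale. The step was a number 19 percentage points higher from compound 1 to compound 3 (beyond the scatter), and set against compound 2 it reads a number 12 percentage points higher from compound 2 to compound 3 (beyond the scatter).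

Compound 4 `CCCCc1cc(C(=O)Nc2nn[nH]n2)nc(-c2cccc(C)c2)c1` has not been measured. It differs from compound 3 by methyl in place of hydrogen on an aromatic carbon. The cores of compound 3 and compound 4 differ from those of compound 1 and compound 2 only by the butyl just described. The change from compound 3 to compound 4 is the same kind of change as that from compound 1 to compound 2, but not the same: in compound 2 the methyl sits on a six-membered aromatic ring with 1 nitrogen, meta to a group of 8 heavy atoms, meta to a phenyl group and opposite the ring nitrogen, whereas in compound 4 it sits on a six-membered aromatic ring of carbon only, meta to a large group.

For compound 4 the step expected in this assay is a number 4 percentage points lower from compound 3 to compound 4 (within the scatter), essentially flat, because the earlier methyl gave only a number 7 percentage points higher from compound 1 to compound 2 (within the scatter) and because compound 3 already reaches 100%, which leaves no room upward. Compound 4 is therefore expected to give about 96%, somewhere between 82% and 100%.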

Compound 4, a percentage reported as inhibition, in the whole organism at one dose (the size of the read-out at that dose, not a potency): 100%
Compound 4: middle estimate off by 4 percentage points, on the low side; low and high end bracket the measured number.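

In this assay, the methyl step on the butyl core reads no change at the digits printed from compound 3 to compound 4 (within the scatter), and on the simpler core it reads a number 7 percentage points higher from compound 1 to compound 2 (within the scatter), so the two cores show no detectable difference in how this change behaves: the same change on two cores in this assay, a number 7 percentage points higher (within the scatter) from compound 1 to compound 2 and no change at the digits printed (within the scatter) from compound 3 to compound 4, 7 percentage points apart, within the scatter of two such steps

This does not show that a methyl has no effect on the butyl core, since compound 3 gives 100% and compound 4 gives 100%, the top of the scale, where any further gain could not appear. Nor is this quite one change tested twice: in compound 4 the methyl sits on a six-membered aromatic ring of carbon only, which is not the ring that carries it in compound 2, and each read-out gives the size of the effect at one dose, not a potency.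

The compounds shown leave open how other groups on that ring, such as a chlorine atom, a methoxy group or an amine, or a chain longer than butyl, would read in this assay. They also leave open whether compound 3 and compound 4 would separate at a lower dose.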